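Lengthening the Chain of Compound 2

This account rests on a few compounds, and the source may have more. Where it says the series, first, only, none or still open, it means among the compounds named here.

In a functional assay on MDA-MB-231 cells (Homo sapiens) for cytotoxicity, read by MTT assay, with a stated time of 24 h (on this read-out lower numbers stand for stronger inhibition and higher numbers for weaker inhibition), compound 2 `CCCCCCCCCC(=O)Nc1nnc(S[C@@H]2O[C@H](CO)[C@H](O)[C@H](O)[C@H]2O)s1` gives 53100 nM, the highest number of the three measured and therefore the weakest inhibition. Compound 1 `CCCCCCCC/C=C\CCCCCCCC(=O)Nc1nnc(S[C@@H]2O[C@H](COC(C)=O)[C@H](OC(C)=O)[C@H](OC(C)=O)[C@H]2OC(C)=O)s1` gives 23600 nM, and compound 3 `CCCCCC(=O)Nc1nnc(S[C@@H]2O[C@H](COC(C)=O)[C@H](OC(C)=O)[C@H](OC(C)=O)[C@H]2OC(C)=O)s1` gives 25400 nM, both clearly lower than compound 2. Compound 4 `CCCCCCCCCCCCCCCC(=O)Nc1nnc(S[C@@H]2O[C@H](CO)[C@H](O)[C@H](O)[C@H]2O)s1` departs from compound 2 in one place: hexyl in place of hydrogen on a saturated chain carbon, nine bonds along the chain from a carbonyl carbon. Within the data shown here, the only measured step that alters a chain is a 1.1-fold higher number from compound 1 to compound 3 (0.03 log units; within the scatter), which lies within the scatter, although both of those compounds also differ from compound 2 elsewhere. No step beyond the scatter is therefore expected in this assay, and the estimate is a 1.2-fold lower number from compound 2 to compound 4 (0.07 log units; within the scatter). The expected value for compound 4 is 45000 nM, with an estimated range from 20000 nM to 95000 nM.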

Compound 4, half-maximal inhibitory concentration: 62300 nM
The estimate for compound 4 lay 1.4-fold (0.14 log units) below the measured number; low and high end bracket the measured number.
By their numbers in this assay, from the lowest: compounds 1 and 3 (each within the scatter of the next); then compounds 2 and 4 (each within the scatter of the next).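

Adding hexyl on a saturated chain carbon, nine bonds along the chain from a carbonyl carbon, gives in this assay a 1.2-fold higher number from compound 2 to compound 4 (0.07 log units; within the scatter). Among these compounds, this is the first direct comparison of chain length with the rest of compound 2 kept unchanged, and it shows no step beyond the scatter, something compound 1 and compound 3 could not show as they differ from compound 2 elsewhere. Nothing measured here explains the result. Still open, going by these compounds, is whether a longer chain, or a chain ending in an amine or a carboxylic acid, would shift the number at this place.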